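This account rests on a few compounds, and the source may have more. Where it says the series, first, only, none or still open, it means among the compounds named here.

Compound 1 `O=S(=O)(CC1=NCCO1)c1n[nH]cc1-c1ccccc1` gives 50.6% in a functional assay, read by Griess assay, with a stated time of 150 min, tested at 50 ug/mL; on this read-out higher numbers stand for a stronger effect at the one concentration tested and lower numbers for a weaker effect. Compound 2 `O=S(=O)(CC1=NCCS1)c1n[nH]cc1-c1ccc(Cl)cc1` gives "not active" (no number reported) in this assay, and compound 3 `Cc1ccc(-c2c[nH]nc2S(=O)(=O)CC2=NCCS2)cc1` gives "not active" (no number reported), each reported as showing no effect with no number given, so compound 3 stands among the entries without a single value, alongside one further such entry. Compound 4 `O=S(=O)(CC1=NCCS1)c1n[nH]cc1-c1ccccc1` has yet to be measured and differs from compound 3 in one place: hydrogen in place of methyl on an aromatic carbon. For the measured compounds named here, compound 3 has no number in this assay, so no step can be computed. A move upward from the unstated level of compound 3 is possible but uncertain; compound 2 also showed no effect. Compound 4 is estimated to give 25%, within a range from 0% to 55%.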

Compound 4, a percentage reported as activity, at one concentration (the size of the read-out at that concentration, not a potency): "not active" (no number reported)
Compound 4 has no reported number here, and the estimate cannot be compared.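

Compound 3 and compound 4 are both reported as not active in this assay with no number given, so no step can be read between them. The compounds shown leave open whether going from 4-methylphenyl to phenyl changes the effect at all. No further evidence bears on this result.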